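The source may hold more compounds than are shown below. What is called first, only, known or untested is meant among the compounds shown, and "the series" means these compounds.

Compound 1 `CCN(Cc1ccccc1)Cc1ccc(CN2CCc3ccc(OS(N)(=O)=O)cc3C2)cc1`: in an assay on HEK293 cells for inhibition of Steryl-sulfatase (Homo sapiens), tested at 1 uM (on this read-out lower numbers stand for a weaker effect and higher numbers for a stronger effect at the one concentration tested), compound 1 gives 17%.
Compound 2 `CCN(Cc1ccc(Br)cc1)c1cccc(C(=O)N2CCc3ccc(OS(N)(=O)=O)cc3C2)c1`: in this assay compound 2 gives 84.5%.
Compound 3 `NS(=O)(=O)Oc1ccc2c(c1)CN(C(=O)c1ccc(N(Cc3ccccc3)Cc3ccco3)cc1)CC2`: in this assay compound 3 gives 98.2%.

Among these three numbers compound 2 stands second highest. Its nearest neighbour is compound 3, whose number lies higher by a margin beyond the usual scatter; its furthest is compound 1, whose number lies far lower, again well beyond the scatter. All three compounds share the same core, and the differences between them lie in the group carried on the nitrogen attached to that core.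

Compound 4 `CCN(Cc1cccc(Br)c1)c1cccc(C(=O)N2CCc3ccc(OS(N)(=O)=O)cc3C2)c1` has not yet been measured. It is built from the same atoms as compound 2, joined differently: 3-bromophenyl in place of 4-bromophenyl on a saturated chain carbon bound to a nitrogen on an aromatic ring. For the measured compounds named here, none of the measured compounds differ from one another in a single place, so no measured step of this kind is available to guide the expectation, and the step from compound 2 to compound 4 can only be judged from the change itself.

Since the bromine merely shifts its position on the same ring while everything else stays as in compound 2, the step of a number 4.5 percentage points lower from compound 2 to compound 4 (within the scatter) is expected to be small, if anything slightly downward, and not clearly beyond the scatter. Compound 4 is therefore estimated at 80%, with a range from 60% to 93%.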

Compound 4, a percentage reported as inhibition, at one concentration (the size of the read-out at that concentration, not a potency): 24.9%
The estimate for compound 4 lay 55.1 percentage points above the measured number; the measured number lies below the stated range.
By their numbers in this assay, from the lowest: compounds 1 and 4 (each within the scatter of the next); then compound 2; then compound 3.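

The change of 4-bromophenyl to 3-bromophenyl on a saturated chain carbon bound to a nitrogen on an aromatic ring gives a number 59.6 percentage points lower from compound 2 to compound 4 (beyond the scatter) in this assay and is a large step, even though the two compounds contain the same atoms. The earlier compounds shown here differed from one another in more than one place, so they could not show that this position is sensitive to where the bromine stands on the ring, with all else held constant. Nothing available accounts for the size of this step, and its origin remains unexplained.

Still open, from the compounds shown here alone, is whether chlorine or a methoxy group in place of the bromine, or a plain phenyl ring without any halogen, would keep a number close to that of compound 2 or fall as compound 4 does. Going by these compounds, it is also open whether the same exchange of 4-bromobenzyl for 3-bromobenzyl would have a step of similar size with a methyl or a propyl chain in place of the ethyl on that nitrogen.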